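A Second Methoxy Group in Two Related Amide Series

The compounds below may be only part of what the source reports. "The series", "measured", "known", "first", "only" and "open" are said of these compounds alone.

Compound 1 `COc1ccc(NC(=O)CCc2cccc3c2B(O)OC3)cc1` is the anchor of this set. In a functional assay on MDA-MB-231 cells (Homo sapiens) for antiproliferative activity, read by MTT assay, with a stated time of 72 h (a higher number here means a weaker inhibitor, a lower number a stronger inhibitor), compound 1 gives 850 nM. Compound 2 `COc1ccc(NC(=O)CCc2cccc3c2B(O)OC3)cc1OC` carries one more methoxy group than compound 1; the difference is methoxy in place of hydrogen on an aromatic carbon. For compound 2 this assay returns only a limit, > 100000 nM, and not a number. The step of an at least 110-fold higher number from compound 1 to compound 2 (2.07 log units; beyond the scatter) is therefore itself at least as large as the distance to that limit, the point named in the limit of > 100000 nM in this assay, at which 1 of the 3 values shown sits.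

Compound 3 `COc1cccc(-c2cccc(NC(=O)CCc3ccc4c(c3)B(O)OC4)c2)c1` belongs to a second core; how the core of compound 3 differs from the core of compound 1 is not broken down here. In this assay compound 3 gives 49000 nM, the highest number among the measured compounds.

Compound 4 `COc1cc(OC)cc(-c2cccc(NC(=O)CCc3ccc4c(c3)B(O)OC4)c2)c1` is not yet measured. It differs from compound 3 by methoxy in place of hydrogen on an aromatic carbon. This is the same kind of change as from compound 1 to compound 2, but not the same change: in compound 2 the entering group sits ortho to a methoxy group and meta to a large group, whereas in compound 4 it sits meta to a large group and meta to a methoxy group, on a different core.

The expectation for compound 4 rests on compound 1 giving 850 nM and compound 3 giving 49000 nM, together with the measured step of an at least 110-fold higher number from compound 1 to compound 2 (2.07 log units; beyond the scatter). The step from compound 3 to compound 4 is expected to be a 2.0-fold higher number from compound 3 to compound 4 (0.31 log units; beyond the scatter). Compound 4 is accordingly estimated at 100000 nM, somewhere between 25000 nM and 400000 nM, with a real chance that this assay reports only a limit.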

Compound 4, half-maximal inhibitory concentration: 21000 nM
Beside the measured number, compound 4's estimate is 4.8-fold (0.68 log units) above it; the measured number lies below the stated range.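

In this assay the change from 3-methoxyphenyl to 3,5-dimethoxyphenyl gives a 2.3-fold lower number from compound 3 to compound 4 (0.37 log units; beyond the scatter) and thus does not repeat the sharp loss seen when compound 1 took up its second methoxy group. Set beside that earlier step, the same kind of change does not carry over from one core to the other, and the two steps run in opposite directions: the same change on two cores in this assay, an at least 110-fold higher number (2.07 log units; beyond the scatter) from compound 1 to compound 2 and a 2.3-fold lower number (0.37 log units; beyond the scatter) from compound 3 to compound 4, at least 270-fold (2.43 log units) apart, beyond the scatter of two such steps. Compound 2 has only a limit, > 100000 nM, and the two pairs differ in where the methoxy group enters as well as in their core, and these compounds do not tell which of those two differences separates the steps.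

The compounds shown leave open whether a second methoxy group placed on the core of compound 1 as it is placed in compound 4 would behave like the step to compound 4 or like the step to compound 2, and whether the reverse placement on the core of compound 3 would do the same. They also leave open whether a hydroxyl group, a fluorine atom or an amine entering in place of that second methoxy group would follow either step, and whether a longer chain before the amide would change the picture on either core.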